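The source may report more compounds than this note shows. Statements on the series, on what has been measured and on what is new or still open speak of the compounds shown alone.

In an ADME assay on MDCK cells (Canis lupus familiaris) for cytotoxicity, read by MTT assay, with a stated time of 2 days (on this read-out lower numbers stand for higher toxicity in this test and higher numbers for lower toxicity in this test), compound 1 (`BrCCCc1ccc(-c2ccc(-c3ccc(-c4cccs4)s3)s2)s1`) gives > 200000 nM as its reading, and this is a limit of the assay and not a number. Compound 2 (`BrCCCCc1ccc(-c2ccc(-c3ccc(-c4cccs4)s3)s2)s1`) has no number: its entry reads "not determined" (no result reported) and it takes no place of its own on this scale. Among the measured compounds shown here, the only reading next to it is the limit of > 200000 nM in this assay, at which 1 of the 2 values shown sits, and that limit belongs to compound 1.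

Compound 3 (`NCCCc1ccc(-c2ccc(-c3ccc(-c4cccs4)s3)s2)s1`) follows from compound 2 by one change (amino in place of bromomethyl on a saturated chain carbon, three bonds along the chain from an aromatic carbon) with amino in place of bromomethyl on a saturated chain carbon, three bonds along the chain from an aromatic carbon. Cut one bond further out, this reads 4-bromobutyl to 3-aminopropyl.

For the measured compounds named here, no measured step is available to size this change. A moderate step toward lower numbers in this assay is expected, meaning higher toxicity in this test, though this is a judgement and not a measured trend. A reading at the same limit as compound 1 also remains possible. For compound 3 the expected value is 60000 nM with an estimated range from 12000 nM to 200000 nM on this read-out.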

Compound 3, half-maximal cytotoxic concentration: > 200000 nM
Compound 3: a limit, no number; the forecaster's own chance of this, stated with the estimate: 35%; middle value at least 3.3-fold (0.52 log units) from the limit.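

No step can be read between compound 1 and compound 3, as both readings are limits and not numbers. The same limit holds for both: the limit of > 200000 nM in this assay, at which 2 of the 3 values shown sit.

The compounds shown leave open whether any change on the chain brings a numerical reading on this scale, and how large such a change would be.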